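The compounds below may be only part of what the source reports. "The series", "measured", "known", "first", "only" and "open" are said of these compounds alone.

Of the compounds shown here, three have so far been tested in an assay on isolated protein for inhibition of protein kinase C zeta type (Homo sapiens), with a stated time of 4 min, tested at 62.5 uM; a higher number here means more inhibition at the concentration tested (going by the name of the read-out), a lower number less inhibition. Compound 1, `CC(C)c1ccc(N2N=C(C(C)(C)C)CC2c2ccc(O)cc2)cc1`, gives 54.9%; compound 2, `Oc1ccc(C2CC(c3ccccc3)=NN2c2cccc(Cl)c2)cc1`, gives 90.5%; and compound 3, `CC(C)(C)C1=NN(c2ccc(Cl)cc2)C(c2ccc(F)cc2)C1`, gives 0%. Compound 3 thus stands lowest of the three, beyond the scatter below both compound 1 and compound 2. Compound 4, `CC(C)(C)C1=NN(c2ccc(Cl)cc2)C(c2ccc(O)c(F)c2)C1`, differs from compound 3 in one place: 3-fluoro-4-hydroxyphenyl in place of 4-fluorophenyl on a saturated ring carbon. Within the data shown here, no measured pair shows this exact change. Still, compound 1 and compound 2 both carry a phenyl with a hydroxyl on the saturated ring carbon and both inhibit, so a rise beyond the scatter is expected, roughly a number 45 percentage points higher from compound 3 to compound 4 (beyond the scatter). Compound 4 is therefore expected to give about 45%, within a range from 10% to 80%.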

Compound 4, a percentage reported as inhibition, at one concentration (the size of the read-out at that concentration, not a potency): 98.5%
For compound 4 the middle estimate is 53.5 percentage points below the measured one; measured number above the stated range.
By their numbers in this assay, from the lowest: compound 3; then compound 1; then compounds 2 and 4 (each within the scatter of the next).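

Putting 3-fluoro-4-hydroxyphenyl in place of 4-fluorophenyl on the saturated ring carbon gives a number 98.5 percentage points higher from compound 3 to compound 4 (beyond the scatter) in this assay. Among these compounds, this is the first comparison that isolates this position, and it shows that the group there can alone separate no measurable inhibition from strong inhibition on this core. No measurement shown explains the size of this step. The compounds shown leave open whether the hydroxyl alone accounts for the step, or whether it needs the fluorine on the same ring. They also leave open whether an amine or a carboxylic acid could replace that hydroxyl.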